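Compound 2 to compound 3: propylcarbonyl to propanoyl

A few compounds are considered here, and "the series" means these few. Any claim that something is new, unique, unknown or untested is made for them only; others in the source may bear on it.

Compound 1 `C=CCOC(=O)SCCCCCCNC(=O)c1cc(-c2ccncc2)n[nH]1`: 32900 nM
Compound 2 `CCCC(=O)SCCCCCCNC(=O)c1cc(-c2ccncc2)n[nH]1`: 23500 nM

Both values come from a functional assay on HCT-116 cells (Homo sapiens) for inhibition, read by MTT assay, with a stated time of 96 h; on this read-out lower numbers stand for stronger inhibition of growth and higher numbers for weaker inhibition of growth. Among the measured compounds shown here, compound 2 stands within the scatter of compound 1, the only other measured compound, so the two cannot be ranked. Compound 3 `CCC(=O)SCCCCCCNC(=O)c1cc(-c2ccncc2)n[nH]1` has not yet been measured. It differs from compound 2 by hydrogen in place of methyl on a saturated chain carbon, two bonds along the chain from a carbonyl carbon. For the measured compounds named here, one measured step bears on this, and only indirectly: a 1.4-fold lower number from compound 1 to compound 2 (0.15 log units; within the scatter), which puts propyl in place of allyloxy on a carbonyl carbon. Going by the values given here, no measured step covers this exact difference. No step beyond the scatter is therefore expected in this assay. The expected step is a 1.1-fold higher number from compound 2 to compound 3 (0.03 log units; within the scatter). For compound 3 the estimated value is 25000 nM, with an expected range of 12000 nM to 50000 nM.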

Compound 3, concentration for 50% growth inhibition: > 50000 nM
Compound 3: only a limit was reported (the forecaster's own chance of this, stated with the estimate: 5%); middle value at least 2.0-fold (0.30 log units) away from the limit.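

In this assay compound 3 gives > 50000 nM as its result, a limit of the assay and not a number. Hydrogen in place of methyl on a saturated chain carbon, two bonds along the chain from a carbonyl carbon, gives an at least 2.1-fold higher number from compound 2 to compound 3 (0.32 log units; beyond the scatter) at this place, so the loss of 1 carbon here moves the read-out beyond the scatter, which the earlier swap of propyl for allyloxy did not do. Against the other measured compound the result gives an at least 1.5-fold higher number from compound 1 to compound 3 (0.18 log units; that floor lies within the scatter) and no more, a floor that does not separate the two.

As far as these compounds go, how far compound 3 lies past its limit stays open, and with it the true size of both steps. Also open, from the compounds shown here alone, is whether a longer chain, such as butyl, or an amine or a carboxylic acid at this place would keep the number near that of compound 2 or shift it further.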